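The source may report more compounds than this note shows. Statements on the series, on what has been measured and on what is new or still open speak of the compounds shown alone.

Measured in a functional assay on HCC 2998 cells (Homo sapiens) for cytotoxicity, read by sulforhodamine B assay, with a stated time of 48 h; a lower number here means a stronger inhibitor of growth, a higher number a weaker inhibitor of growth:
Compound 1 `Nc1nc(Cl)c2ncn(Cc3ccccc3CCl)c2n1` gives 6610 nM.
Compound 2 `ClCc1ccccc1Cn1cnc2nc(Cl)nc(Cl)c21` gives 35500 nM.
Compound 3 `ClCc1ccccc1Cn1cnc2c(Cl)nc(Cl)nc21` gives 3380 nM.

Compound 3 holds the lowest number of the three; compound 1 lies within the scatter of it, while compound 2 sits well apart, beyond the scatter, as the two values show. Within the data shown here, the only single-change step measured is a 2.0-fold lower number from compound 1 to compound 3 (0.29 log units; within the scatter), within the scatter. Compound 4 `ClCc1ccccc1Cn1cnc2c(Cl)ncnc21` differs from compound 3 as follows: hydrogen in place of chloro on an aromatic carbon. No measured step removes a chloro, so the amino-to-chloro step bears on this only indirectly; a small shift in this assay is expected, with no strong reason for either direction. The estimate for compound 4 is 5000 nM, range 2000 nM to 15000 nM, meaning a 1.5-fold higher number from compound 3 to compound 4 (0.17 log units; within the scatter) is expected.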

Compound 4, concentration for total growth inhibition: 3540 nM
Compound 4: middle estimate off by 1.4-fold (0.15 log units), on the high side; the range from low to high includes it.
By their numbers in this assay, from the lowest: compounds 3, 4 and 1 (each within the scatter of the next); then compound 2.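

Working notes: in this assay, the aromatic carbon between two ring nitrogen atoms has now been read with chloro, amino and hydrogen. Hydrogen in place of chloro (a 1.0-fold higher number from compound 3 to compound 4 (0.02 log units; within the scatter)) and hydrogen in place of amino (a 1.9-fold lower number from compound 1 to compound 4 (0.27 log units; within the scatter)) both stay within the scatter, so the chloro on this carbon is not required to keep the number of compound 3, and none of the three groups separates from the others. No measurement available here explains this result.

Still open, going by these compounds, is whether a larger group on this carbon, such as methoxy or a dimethylamino group, would also stay within the scatter. The contribution of the remaining chloro on this ring, meta to this carbon, is also unresolved.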